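A few compounds are considered here, and "the series" means these few. Any claim that something is new, unique, unknown or untested is made for them only; others in the source may bear on it.

Working notes on the series.

Three compounds have numbers in an ADME assay on microsomes from liver (Homo sapiens) for metabolic stability; a higher number here means that the compound lasts longer, a lower number that the compound disappears faster. Compound 1 `CCC(CC)(c1nnc[nH]1)c1ccc(-c2ccc3cc(F)cc(F)c3c2)[nH]c1=O` gives 1.76 h in this assay. Compound 2 `CCn1ncc2c(F)cc(-c3ccc(C(CC)(CC)c4nncn4C)c(=O)[nH]3)cc21` gives 2.67 h in this assay. Compound 3 `CC(C)C(c1ccc(-c2ccc3cccc(F)c3c2)[nH]c1=O)N1CCN/C1=N\C#N` gives 0.632 h in this assay, the lowest of the three numbers: compound 1 is the nearest to it, with a higher number beyond the scatter, and compound 2 is the furthest, also beyond the scatter. Among the measured compounds shown here, no pair among the three differs in a single place, so no step between measured compounds is available.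

Compound 4 `CC(C)C(/C=C1\CCNC1=O)c1ccc(-c2ccc3cccc(F)c3c2)[nH]c1=O` has not yet been measured in this assay. It differs from compound 3 in one place: a group of 7 heavy atoms (5 carbon, 1 nitrogen, 1 oxygen; one five-membered non-aromatic ring with 1 hetero atom) in place of a group of 8 heavy atoms (4 carbon, 4 nitrogen; one five-membered non-aromatic ring with 2 hetero atoms), on a saturated chain carbon bound to an aromatic carbon and a saturated chain carbon. The shared core and the rest of the molecule are unchanged.

For the measured compounds named here, nothing among the measured compounds shows how this exchange acts on the half-life, and the three numbers give no step of the same kind. The expectation for compound 4 is therefore anchored on compound 3 and its value 0.632 h, with a step of a 1.1-fold higher number from compound 3 to compound 4 (0.04 log units; within the scatter) that is expected to stay within the usual scatter, in no clear direction. Compound 4 is estimated at 0.7 h, with a range from 0.3 h to 1.6 h.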

Compound 4, half-life: 0.713 h
Beside the measured number, compound 4's estimate is 1.0-fold (0.01 log units) below it, and the stated range covers the measured number.
By their numbers in this assay, from the lowest: compounds 3 and 4 (each within the scatter of the next); then compounds 1 and 2 (each within the scatter of the next).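

On the saturated chain carbon bound to an aromatic carbon and a saturated chain carbon, the exchange of the group of 8 heavy atoms (4 carbon, 4 nitrogen) for the group of 7 heavy atoms (5 carbon, 1 nitrogen, 1 oxygen) gives a 1.1-fold higher number from compound 3 to compound 4 (0.05 log units; within the scatter) in this assay. Among the compounds shown here, this is the first single-place step, and it shows that these two groups, each with a five-membered non-aromatic ring, cannot be told apart by half-life at this position. No measurement on hand explains this result.

Going by these compounds, whether an amine or a carboxylic acid on this carbon would give a different half-life remains open. Also open, on these data alone, is whether this exchange would give a similar step on the core of compound 1 or on that of compound 2.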